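The source may hold more compounds than are shown below. What is called first, only, known or untested is meant among the compounds shown, and "the series" means these compounds.

Three compounds have been measured in an ADME assay on MT2 cells (Homo sapiens) for cytotoxicity, read by XTT assay, with a stated time of 4 days; a higher number here means that more compound is tolerated, a lower number that less compound is tolerated:
compound 1 `Cc1ccc(C)n1-c1ccc(S(N)(=O)=O)cc1` gives 117000 nM;
compound 2 `O=C(O)c1cc(N2C(=O)CSC2=S)ccc1Cl` gives 155000 nM;
compound 3 `O=C(O)c1cc(-n2cccc2)ccc1O` gives 493000 nM.

Compound 2 sits between the other two. Its number and that of compound 1 lie within the usual scatter, so the two cannot be told apart; compound 3, however, tolerates clearly more compound than compound 2, a gap beyond the scatter. Compound 4 `O=C(O)c1cc(N2C(=O)CSC2=S)ccc1O` is the unmeasured partner of compound 2: hydroxy in place of chloro on an aromatic carbon. Going by the values given here, no measured pair shows this exact change, so the step in this assay can only be guessed. The hydroxy-bearing compound 3, with its 493000 nM, hints at more tolerated compound, but a step within the scatter is expected, namely a 1.3-fold higher number from compound 2 to compound 4 (0.11 log units; within the scatter). Compound 4 is estimated at 200000 nM, ranging from 90000 nM to 450000 nM.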

Compound 4, half-maximal cytotoxic concentration: 152000 nM
Beside the measured number, compound 4's estimate is 1.3-fold (0.12 log units) above it; measured number inside the range.
By their numbers in this assay, from the lowest: compounds 1, 4 and 2 (each within the scatter of the next); then compound 3.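

On the ring of compound 2, replacing chloro with hydroxy at the carbon ortho to a carboxy group gives a 1.0-fold lower number from compound 2 to compound 4 (0.01 log units; within the scatter) in this assay, so the two compounds cannot be told apart. This single exchange adds a hydrogen-bond donor and a hydrogen-bond acceptor, yet it leaves no detectable mark on the tolerated concentration. Nothing available offers a reason for this result. From the compounds shown here alone, whether an amine or a methoxy group at the same carbon would behave alike remains open. So does whether this exchange would give the same result on a different core.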